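The source may report more compounds than this note shows. Statements on the series, on what has been measured and on what is new or still open speak of the compounds shown alone.

Compound 1 `CCOc1c(-c2cc(OC)c(OC)c(OC)c2)oc2ccccc2c1=O` is the anchor of this small set. For the measured compounds named here, in a functional assay on DU-145 cells (Homo sapiens) for antiproliferative activity, read by WST assay, with a stated time of 3 days (a lower number here means a stronger inhibitor, a higher number a weaker inhibitor), compound 1 gives 6200 nM, and this is the only actual number among the three values in hand. Compound 2 `CCN(CC)CCCOc1c(-c2cc(OC)c(OC)c(OC)c2)oc2ccccc2c1=O` gives > 50000 nM, which is a limit of this assay rather than a number. Compound 3 `CCCN(CCC)CCCOc1c(-c2cc(OC)c(OC)c(OC)c2)oc2ccccc2c1=O` gives > 50000 nM, again a limit of this assay.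

Going by the values given here, two measured steps bear on the move to compound 4. The step of an at least 8.0-fold higher number from compound 1 to compound 2 (0.90 log units; beyond the scatter) shows a clear loss of potency, and the step of an at least 8.0-fold higher number from compound 1 to compound 3 (0.90 log units; beyond the scatter) shows the same. The step that the two limits leave unreadable from compound 2 to compound 3 cannot be sized, since both ends are limits.

Compound 4 `CCCCN(CCCC)CCCCOc1c(-c2cc(OC)c(OC)c(OC)c2)oc2ccccc2c1=O` goes further in the same direction: 2-(dibutylamino)ethyl in place of hydrogen on a saturated chain carbon, two bonds along the chain from an oxygen on an aromatic ring. Both smaller amino-bearing chains already pushed the value out of the measurable range, so a weaker inhibitor than compound 1 is expected here too, and the result is likely to be another limit because of the limit of > 50000 nM in this assay, at which 2 of the 3 values shown sit. The expected step is an 11-fold higher number from compound 1 to compound 4 (1.05 log units; beyond the scatter). Compound 4 is therefore estimated at 70000 nM, with a likely range from 20000 nM to 250000 nM.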

Compound 4, half-maximal inhibitory concentration: 15300 nM
For compound 4 the middle estimate is 4.6-fold (0.66 log units) above the measured one; the measured number lies below the stated range.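

In this assay, the step of a 2.5-fold higher number from compound 1 to compound 4 (0.39 log units; beyond the scatter) shows that an amino-bearing chain on this saturated chain carbon still costs potency, but that such a chain need not push the value out of the measurable range. Set against the two smaller amines, whose values are limits of the assay and not numbers, the new compound stands clearly apart: the steps are an at least 3.2-fold lower number from compound 3 to compound 4 (0.51 log units; beyond the scatter) and an at least 3.2-fold lower number from compound 2 to compound 4 (0.51 log units; beyond the scatter). Each of these two steps changes the groups on the nitrogen and the length of the chain together, so the gain belongs to the two changes as a pair and cannot be credited to either one alone.

On these data alone, what stays open is which of the two changes carries the gain: a dibutylamino group on the chain of compound 3, or a diethylamino group on the chain of compound 4, would separate them. Also open, as far as these compounds go, is whether a ring amine such as piperidine or morpholine, or a still longer chain, would narrow the remaining gap to compound 1 or close it.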